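The source may report more compounds than this note shows. Statements on the series, on what has been measured and on what is new or still open speak of the compounds shown alone.

Measured so far in an assay on membranes from HEK293 cells for displacement of a labelled ligand from adenosine receptor A2b (Homo sapiens), read by scintillation counting, with a stated time of 30 min; a lower number here means a stronger inhibitor, a higher number a weaker inhibitor:
compound 1 `CCCOC(=O)C1=C(C)NC(=O)NC1c1ccoc1`: 1190 nM
compound 2 `CCCOC(=O)C1=C(C)NC(=O)NC1c1cccs1`: 1520 nM

Compound 2 gives the highest of the two numbers, and its nearest neighbour is compound 1. Going by the values given here, the only measured step, a 1.3-fold higher number from compound 1 to compound 2 (0.11 log units; within the scatter), places thiophen-2-yl in place of furan-3-yl on a saturated ring carbon and leaves the two numbers within the scatter of each other.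

Compound 3 `CC1=C(C(=O)OCC2CC2)C(c2cccs2)NC(=O)N1` carries cyclopropyl in place of ethyl on a saturated chain carbon bound to an oxygen next to a carbonyl group. Among the compounds with values here, that change sits on a saturated chain carbon bound to an oxygen next to a carbonyl group, a part of the shared core that no measured step has touched, so nothing in the data speaks to it directly. Without any measured step pointing either way, a step no larger than the scatter is expected for a 1.0-fold lower number from compound 2 to compound 3 (0.01 log units; within the scatter). The inhibition constant of compound 3 in this assay is therefore estimated at 1500 nM, with a range from 700 nM to 3200 nM.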

Compound 3, inhibition constant: 1570 nM
Compound 3: middle estimate off by 1.0-fold (0.02 log units), on the low side; low and high end bracket the measured number.
By their numbers in this assay, from the lowest: compounds 1, 2 and 3 (each within the scatter of the next).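

Going by these compounds alone, the step of a 1.0-fold higher number from compound 2 to compound 3 (0.01 log units; within the scatter) is the first reading at this position, a part of the shared core that the earlier step did not touch. In this assay, the exchange of propoxy for cyclopropylmethoxy, which brings one more heavy atom and a three-membered ring of carbon, leaves the two numbers within the scatter of each other, a result that holds for this one pair, with thiophen-2-yl on the saturated ring carbon. No independent measurement bears on why these two numbers lie so close.

The compounds shown leave open whether cyclopropyl reads the same with furan-3-yl on that ring carbon. They also leave open how a longer chain, a phenyl ring or an amine would read at this position.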